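Swapping the urea aryl: difluorophenyl to methylphenyl

This account rests on a few compounds, and the source may have more. Where it says the series, first, only, none or still open, it means among the compounds named here.

Three ureas built on one shared core have been tested in an assay on isolated protein for inhibition of Ephrin type-A receptor 2 (Homo sapiens), read by thermal shift assay, tested at 10 uM; on this read-out lower numbers stand for weaker stabilisation of the target and higher numbers for stronger stabilisation of the target against heat. Compound 1 `CCOc1ccc(NC(=O)Nc2cc(C(C)(C)C)nn2-c2ccccc2)cc1` gives 1 degrees C, compound 2 `CC(C)(C)c1cc(NC(=O)Nc2ccc(F)cc2)n(-c2ccccc2)n1` gives -2.2 degrees C, and compound 3 `CC(C)(C)c1cc(NC(=O)Nc2ccc(F)c(F)c2)n(-c2ccccc2)n1` gives 2.2 degrees C, the highest of the three. Between them, the steps were a number 3.2 degrees C lower from compound 1 to compound 2 (beyond the scatter) and a number 4.4 degrees C higher from compound 2 to compound 3 (beyond the scatter). Compound 4 `Cc1ccc(NC(=O)Nc2cc(C(C)(C)C)nn2-c2ccccc2)cc1` has not been measured; its change from compound 3 is 4-methylphenyl in place of 3,4-difluorophenyl on an amide-type nitrogen. The most telling comparison is the earlier aryl swap, a number 1.2 degrees C higher from compound 1 to compound 3 (beyond the scatter), where the difluorophenyl group came out ahead of another para-substituted phenyl; together with the large loss on removing one fluorine, a modest downward step is expected, a number 1.7 degrees C lower from compound 3 to compound 4 (beyond the scatter). Compound 4 is therefore estimated at 0.5 degrees C, within a range of -2.5 degrees C to 3.5 degrees C.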

Compound 4, shift of the target's melting temperature: 1.7 degrees C
Compound 4: middle estimate off by 1.2 degrees C, on the low side; the measured number falls inside the stated range.
By their numbers in this assay, from the lowest: compound 2; then compounds 1, 4 and 3 (each within the scatter of the next, the first and the last beyond it).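

On an amide-type nitrogen, 4-methylphenyl and 3,4-difluorophenyl cannot be told apart (a number 0.50 degrees C lower from compound 3 to compound 4 (within the scatter)), and the methyl and ethoxy compounds also stay within the scatter (a number 0.70 degrees C higher from compound 1 to compound 4 (within the scatter)). Compound 2 alone stands apart, as methyl in place of its fluoro gives a clear step (a number 3.9 degrees C higher from compound 2 to compound 4 (beyond the scatter)), so this aryl group needs no fluorine to match compound 3. No measured evidence explains these results. From the compounds shown here alone, whether an amine, a carboxylic acid or a longer chain in place of the methyl would match compound 4 remains open.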